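Compound 3: 1,2-dihydroxyethyl for 1,2-diacetoxyethyl

The source may report more compounds than this note shows. Statements on the series, on what has been measured and on what is new or still open speak of the compounds shown alone.

Compound 1 `CC(=O)OC[C@@H](OC(C)=O)[C@H]1O[C@@H](n2cnc3c(Cl)ncnc32)[C@H](OC(C)=O)[C@@H]1OC(C)=O`: > 100000 nM, a limit
Compound 2 `CC(=O)OC[C@@H](OC(C)=O)[C@H]1O[C@@H](n2cnc3c(-c4ccccc4)ncnc32)[C@H](OC(C)=O)[C@@H]1OC(C)=O`: > 100000 nM, a limit
Compound 3 `CC(=O)OC[C@@H](OC(C)=O)[C@H]1O[C@@H](n2cnc3c(Cl)nc(Cl)nc32)[C@H](OC(C)=O)[C@@H]1OC(C)=O`: 22400 nM

All three were tested in a functional assay on MCF7 cells (Homo sapiens), read by colorimetric assay, with a stated time of 96 h; on this read-out lower numbers stand for stronger inhibition and higher numbers for weaker inhibition. Going by the values given here, compound 3 is the only one with a true number. Compound 1 and compound 2 stand at the limit of > 100000 nM in this assay, at which 2 of the 3 values shown sit.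

Compound 4 `CC(=O)O[C@H]1[C@@H](OC(C)=O)[C@H](n2cnc3c(Cl)nc(Cl)nc32)O[C@@H]1[C@H](O)CO` carries 1,2-dihydroxyethyl in place of 1,2-diacetoxyethyl on a saturated ring carbon.

Both measured steps change an aromatic carbon, not this group. The first is an at least 4.4-fold lower number from compound 1 to compound 3 (0.64 log units; beyond the scatter), and compound 4 keeps that added chloro. The other is a step that the two limits leave unreadable from compound 1 to compound 2. Among the compounds with values here, with no direct precedent, the expected step is only a cautious guess: a 2.2-fold higher number from compound 3 to compound 4 (0.35 log units; beyond the scatter), towards a higher number. Compound 4 is estimated at 50000 nM, with an expected range of 15000 nM to 100000 nM.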

Compound 4, half-maximal inhibitory concentration: 36300 nM
For compound 4 the middle estimate is 1.4-fold (0.14 log units) above the measured one; low and high end bracket the measured number.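

In this assay, the change at this saturated ring carbon gives a 1.6-fold higher number from compound 3 to compound 4 (0.21 log units; within the scatter), so the two compounds cannot be told apart here. The earlier steps shown here touched only an aromatic carbon; this one shows that, with the added chloro kept, the much smaller 1,2-dihydroxyethyl can stand in for 1,2-diacetoxyethyl with no difference beyond the scatter. Nothing shown here explains this result.

As far as these compounds go, what an amine or a carboxylic acid would do on this carbon stays open. So does whether the same swap holds on the other cores shown.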